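A few compounds are considered here, and "the series" means these few. Any claim that something is new, unique, unknown or untested is made for them only; others in the source may bear on it.

In a functional assay on MCF7 cells (Homo sapiens) for antiproliferative activity, read by MTT assay, with a stated time of 48 h (on this read-out higher numbers stand for weaker inhibition and lower numbers for stronger inhibition), compound 1 (`N#Cc1ncn(-c2ccc(F)cc2)c1/N=C/c1ccc([N+](=O)[O-])cc1`) gives 9100 nM, compound 2 (`COc1ccc(/C=N/c2c(C#N)ncn2-c2ccc(F)cc2)cc1`) gives 9330 nM and compound 3 (`COc1ccc(/C=N/c2c(C#N)ncn2-c2ccc(F)cc2)cc1OC`) gives 14700 nM, which places compound 3 within the scatter of both others. Compound 4 (`COc1ccc(/C=N/c2c(C#N)ncn2Cc2ccc(F)cc2)cc1OC`) differs from compound 3 at one place, with 4-fluorobenzyl in place of 4-fluorophenyl on an aromatic nitrogen. The two measured steps, a 1.0-fold higher number from compound 1 to compound 2 (0.01 log units; within the scatter) and a 1.6-fold higher number from compound 2 to compound 3 (0.20 log units; within the scatter), lie within the scatter, but both are changes on an aromatic carbon, so neither tests this nitrogen substituent. No step beyond the scatter is expected in this assay, though this expectation is loosely grounded. The expected step is a 1.2-fold lower number from compound 3 to compound 4 (0.09 log units; within the scatter). Compound 4 is estimated at 12000 nM, within a range of 5000 nM to 29000 nM.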

Compound 4, half-maximal inhibitory concentration: 11100 nM
Beside the measured number, compound 4's estimate is 1.1-fold (0.03 log units) above it, and the stated range covers the measured number.
By their numbers in this assay, from the lowest: compounds 1, 2, 4 and 3 (each within the scatter of the next).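

In this assay, within the data shown here, the substituent on the aromatic nitrogen is varied for the first time, whereas the earlier steps changed only an aromatic carbon. Placing 4-fluorobenzyl in place of 4-fluorophenyl gives a 1.3-fold lower number from compound 3 to compound 4 (0.12 log units; within the scatter), so on the core of compound 3 this change at this position produces no step beyond the scatter. Nothing available offers an explanation for this result. The compounds shown leave open whether a longer alkyl chain or a chain ending in an amine on this nitrogen would also stay within the scatter, and whether the benzyl change would read the same on compound 1 or compound 2.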